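Exchanging the nitrile-bearing ring on an aromatic ether

A few compounds are considered here, and "the series" means these few. Any claim that something is new, unique, unknown or untested is made for them only; others in the source may bear on it.

Measured so far in a physicochemical assay for lipophilicity; on this read-out higher numbers stand for higher lipophilicity and lower numbers for lower lipophilicity:
compound 1 `CCn1cnc2c(-c3ccc(F)c(Oc4ccnc(C)c4)c3)cnnc21` gives 2.6
compound 2 `CCn1cnc2c(-c3ccc(F)c(OCc4ccccn4)c3)cnnc21` gives 2.5
compound 3 `CCn1cnc2c(-c3ccc(F)c(Oc4cnc(C#N)nc4)c3)cnnc21` gives 2

Of these three, compound 3 (2) stands lowest, and compound 1 and compound 2 both lie beyond the scatter above it. Compound 4 `CCn1cnc2c(-c3ccc(F)c(Oc4ccc(C#N)cn4)c3)cnnc21` has not yet been measured. It has 5-cyanopyridin-2-yl in place of 2-cyanopyrimidin-5-yl on an oxygen on an aromatic ring, which in full is 5-cyanopyridin-2-yl in place of 2-cyanopyrimidin-5-yl on an oxygen on an aromatic ring and leaves the rest of compound 3 untouched.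

For the measured compounds named here, no measured step makes this exact exchange. The nearest are a number 0.60 log units lower from compound 1 to compound 3 (beyond the scatter) and a number 0.50 log units lower from compound 2 to compound 3 (beyond the scatter) as the two modest steps that end in the group compound 4 gives up, and each of them starts from a pyridinyl group. Both steps also change more than the present exchange does, as the nitrile stays in compound 4, so only part of their size is expected to return, in the opposite direction. In this assay the expected change is therefore an upward one, estimated as a number 0.40 log units higher from compound 3 to compound 4 (beyond the scatter) and not certain to clear the scatter. The estimate for compound 4 is 2.4 with 2 to 2.8 as the expected range.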

Compound 4, distribution coefficient: 2.3
The estimate for compound 4 lay 0.10 log units above the measured number, within the range that was stated.
By their numbers in this assay, from the lowest: compounds 3, 4, 2 and 1 (each within the scatter of the next, the first and the last beyond it).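

In this assay, keeping the nitrile and exchanging only the ring that carries it, a ring with 1 hetero atom in place of one with 2 hetero atoms, gives a number 0.30 log units higher from compound 3 to compound 4 (within the scatter), so this exchange on an oxygen on an aromatic ring does not clearly separate the two compounds. The group that enters also leaves compound 4 within the scatter of the two compounds whose groups carry no nitrile, with a number 0.20 log units lower from compound 2 to compound 4 (within the scatter) and a number 0.30 log units lower from compound 1 to compound 4 (within the scatter). A nitrile-bearing ring at this place therefore does not in itself set a compound apart on this read-out: compound 3 lies beyond the scatter of compounds 1 and 2, while compound 4 does not. No measurement offered here accounts for these numbers.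

The compounds shown leave open how a plain pyridin-2-yl group, which would have the ring of compound 4 without its nitrile, would compare with 5-cyanopyridin-2-yl. They also leave open how this read-out would respond to an amine or a carboxylic acid on the ring at this oxygen.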